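This account rests on a few compounds, and the source may have more. Where it says the series, first, only, none or still open, it means among the compounds named here.

Compounds 1, 2 and 3 share a common core and differ only in one group. Compound 1 `COc1cc(OC)c(OC)cc1/C=C/COC(=O)/C=C/c1ccc(OC)c(OC)c1OC`, compound 2 `COc1cc(OC)c(OC)cc1/C=C/COC(=O)/C=C/c1c(OC)ccc(OC)c1OC` and compound 3 `COc1cc(OC)c(OC)cc1/C=C/COC(=O)/C=C/c1ccc(F)cc1` were each tested in a functional assay on the whole organism (strain Kunming) with Mus musculus as the target, with a stated time of 0.5 h, at a dose of 300 mg/kg by the intraperitoneal route; on this read-out higher numbers stand for a weaker effect at the one dose given and lower numbers for a stronger effect. Compound 1 gives 75%, compound 2 gives 75% and compound 3 gives 75%. Compound 3 thus stands level with compounds 1 and 2 at the digits reported, the gaps among the three lying within the usual scatter. Compound 4 `COc1cccc(/C=C/C(=O)OC/C=C/c2cc(OC)c(OC)cc2OC)c1` has not yet been measured in this assay. It differs from compound 3 in one place: 3-methoxyphenyl in place of 4-fluorophenyl on a double-bonded chain carbon bound to a double-bonded chain carbon. Among the compounds with values here, no step between measured compounds that differ in one place is available, so the size of this change cannot be read from the data. The step of no change at the digits printed from compound 3 to compound 4 (within the scatter) is expected to be none beyond the scatter. Compound 4 is therefore expected to give 75%, within 60% to 90%.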

Compound 4, a percentage reported as activity, at one dose (the size of the read-out at that dose, not a potency): 75%
For compound 4 middle estimate and measured number coincide at the digits printed; the range from low to high includes it.
By their numbers in this assay, from the lowest: compounds 1, 2, 3 and 4 (each within the scatter of the next).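

In this assay, the exchange at this position on a double-bonded chain carbon bound to a double-bonded chain carbon gives no change at the digits printed from compound 3 to compound 4 (within the scatter). Within the data shown here, this is the first step here between compounds that differ in one place, and it shows that 3-methoxyphenyl, with one hydrogen-bond acceptor, and 4-fluorophenyl, with none, cannot be told apart on this read-out. Nothing available bears on the reason for this outcome. The compounds shown leave open whether an amine or a carboxylic acid in place of 3-methoxyphenyl would shift the read-out. They also leave open whether a saturated alkyl chain could replace the aromatic ring here without a shift.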